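This account rests on a few compounds, and the source may have more. Where it says the series, first, only, none or still open, it means among the compounds named here.

In a functional assay on HCT-116 cells (Homo sapiens) for inhibition, read by MTT assay, with a stated time of 72 h (on this read-out lower numbers stand for stronger inhibition and higher numbers for weaker inhibition), compound 1 `Cc1nc(-c2ccccc2F)c(C(=O)N2CCN(c3cc(Cl)cc(Cl)c3)CC2)o1` gives 319 nM. Compound 3 `CCC[C@H](Nc1nc(-c2ccc(NC(=O)NCC)c(OC)c2)ncc1C)c1cccnc1`, a structurally different molecule, gives 356 nM, which is within the scatter of compound 1. Compound 2 `COc1cc(OC)cc(N2CCN(C(=O)c3oc(C)nc3-c3ccccc3F)CC2)c1` gives 26 nM, clearly lower than both.

Compound 4 `Cc1nc(-c2cccc(F)c2)c(C(=O)N2CCN(c3cc(Cl)cc(Cl)c3)CC2)o1` differs from compound 1 in a single group: 3-fluorophenyl in place of 2-fluorophenyl on an aromatic carbon. In short, 3-fluorophenyl stands in place of 2-fluorophenyl on an aromatic carbon, so the same atoms are joined differently.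

For the measured compounds named here, only one measured step bears on this change, and only indirectly. It is a 12-fold lower number from compound 1 to compound 2 (1.09 log units; beyond the scatter), a large step made by placing 3,5-dimethoxyphenyl in place of 3,5-dichlorophenyl on an amine nitrogen in a ring. Going by the values given here, no measured pair tests a change in the fluorophenyl group, so the data give no direction. That large step does show that one substitution on this shared core can matter, which argues for a wide range.

The expected change is a 1.0-fold higher number from compound 1 to compound 4 (0.00 log units; within the scatter), with no step beyond the scatter anticipated. For compound 4, the estimated value is 320 nM, within an expected range of 110 nM to 950 nM.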

Compound 4, half-maximal inhibitory concentration: 366 nM
The estimate for compound 4 lay 1.1-fold (0.06 log units) below the measured number; the range from low to high includes it.
By their numbers in this assay, from the lowest: compound 2; then compounds 1, 3 and 4 (each within the scatter of the next).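

Shifting the fluorine from 2-fluorophenyl to 3-fluorophenyl gives a 1.1-fold higher number from compound 1 to compound 4 (0.06 log units; within the scatter) in this assay, so this first test of the fluorophenyl group finds no measurable effect of where the fluorine sits, at least with the 3,5-dichlorophenyl group kept in place. The shared core is therefore not sensitive to every change, since the swap on the ring amine nitrogen gave a 12-fold lower number from compound 1 to compound 2 (1.09 log units; beyond the scatter), while this one stays within the scatter. No measurement available here explains why the two fluorine placements read alike.

As far as these compounds go, whether they would also read alike with the 3,5-dimethoxyphenyl group of compound 2 remains open. So does what would happen with a plain phenyl group at this position, or with an amine or a carboxylic acid on that ring in place of the fluorine.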